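Dichlorophenyl to Difluorophenyl: Expectation for Compound 4

The compounds below may be only part of what the source reports. "The series", "measured", "known", "first", "only" and "open" are said of these compounds alone.

Compound 1 `COc1cc(-c2cc(/C=C/C(=O)c3ccc(Cl)c(Cl)c3)[nH]n2)cc(OC)c1OC` was tested in a functional assay on IGROV-1 cells (Homo sapiens) for inhibition, read by sulforhodamine B assay, with a stated time of 48 h; on this read-out higher numbers stand for lower toxicity in this test and lower numbers for higher toxicity in this test. In this assay compound 1 gives > 100000 nM, which is a limit of the assay and not a measured number; it stands at the limit of > 100000 nM in this assay, at which 1 of the 3 values shown sits. Two related compounds do give numbers in this assay: compound 2 `COc1ccc(-c2cc(/C=C/C(=O)c3ccc(N)cc3)[nH]n2)cc1OC` gives 73000 nM, and compound 3 `COc1cc(C(=O)/C=C/c2cc(-c3cc(OC)c(OC)c(OC)c3)n[nH]2)cc(OC)c1OC` gives 33100 nM. Compound 4 `COc1cc(-c2cc(/C=C/C(=O)c3ccc(F)c(F)c3)[nH]n2)cc(OC)c1OC` has not yet been measured. It differs from compound 1 in one place: 3,4-difluorophenyl in place of 3,4-dichlorophenyl on a carbonyl carbon. No measured pair of this kind exists among these compounds to show how large such a swap matters. The expected step is therefore a number no higher from compound 1 to compound 4 (the limit leaves the size open), no larger than the usual scatter, with a fair chance that only a limit is reported again. Compound 4 is estimated at 100000 nM, spanning 40000 nM to 300000 nM.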

Compound 4, concentration lethal to 50% of the cells: > 100000 nM
Compound 4: no number, only a limit (the forecaster's own chance of this, stated with the estimate: 60%); the middle value sits exactly at the limit.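

Among the compounds shown here, compound 1 and compound 4 each give only a limit in this assay, not a number, and no step between them can be read. The compounds shown leave open whether 3,4-difluorophenyl in place of 3,4-dichlorophenyl changes the value at all.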